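Swapping the Aryl Arm on a Weak Hydrazone Inhibitor

The compounds below may be only part of what the source reports. "The series", "measured", "known", "first", "only" and "open" are said of these compounds alone.

Three hydrazone-thiazoles have been measured in a functional assay on Caco-2 cells (Homo sapiens) for inhibition, read by MTT assay, with a stated time of 48 h (a lower number here means a stronger inhibitor, a higher number a weaker inhibitor), so far. Compound 1 `COc1cc(/C=N/Nc2nc(-c3ccc(C(F)(F)F)cc3)cs2)c(Br)c(Br)c1OC` carries two bromines and two methoxy groups on the benzylidene side together with a 4-(trifluoromethyl)phenyl group on the shared core. For compound 1 the assay reports only a limit, > 100000 nM, and that limit is described by the limit of > 100000 nM in this assay, at which 1 of the 3 values shown sits. Compound 2 `Fc1ccc(/C=N/Nc2nc(-c3ccc(F)c(F)c3)cs2)cc1F` gives 14200 nM in this assay, and compound 3 `Fc1ccc(/C=N/Nc2nc(-c3ccc(Br)cc3)cs2)cc1F` gives 43900 nM. Among the compounds with values here, the one measured step between single-point neighbours, a 3.1-fold higher number from compound 2 to compound 3 (0.49 log units; beyond the scatter), is the only change on the aryl arm of the core with a numerical read-out.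

Compound 4 `COc1cc(/C=N/Nc2nc(-c3cccc(Br)c3)cs2)c(Br)c(Br)c1OC` keeps the tetrasubstituted benzylidene of compound 1 and differs only there: 3-bromophenyl in place of 4-(trifluoromethyl)phenyl on an aromatic carbon. The step from compound 2 to compound 3 also exchanged a fluorinated phenyl for a bromophenyl and moved the number modestly upward, but it was measured from a compound with a real value, whereas compound 1 sits at the limit. Within the data shown here, with no measured step starting from a limit, the expectation for compound 4 is an unchanged standing, so the estimated step of a number no higher from compound 1 to compound 4 (the limit leaves the size open) is none beyond the scatter. Compound 4 is therefore expected to give about 100000 nM in this assay, with a range from 30000 nM to 300000 nM, and most likely again only a limit.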

Compound 4, half-maximal inhibitory concentration: > 100000 nM
Compound 4: no number, only a limit (the forecaster's own chance of this, stated with the estimate: 65%); the middle value sits exactly at the limit.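

Compound 1 and compound 4 both stand only as limits in this assay, and the exchange of 4-(trifluoromethyl)phenyl for 3-bromophenyl between them gives no readable step: the limit of > 100000 nM in this assay, at which 2 of the 4 values shown sit. The compounds shown leave open whether any aryl arm on the shared core, alongside the two bromines and two methoxy groups, would give a measured number in this assay.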